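Growth inhibition notes: from compound 1 to compound 4

This account rests on a few compounds, and the source may have more. Where it says the series, first, only, none or still open, it means among the compounds named here.

compound 1 `CN1CCN(CCCOc2cccc3nc(Nc4ccc(Cl)c(C(F)(F)F)c4)ccc23)CC1` gives 1390 nM
compound 2 `CN1CCN(CCCOc2cccc3nc(Nc4ccc(Cl)c(F)c4)ccc23)CC1` gives 1720 nM
compound 3 `CN1CCN(CCCOc2cccc3nc(Nc4ccc(F)c(F)c4)ccc23)CC1` gives 1080 nM

All three values come from a functional assay on SK-MEL-28 cells (Homo sapiens) for inhibition, read by sulforhodamine B assay, with a stated time of 48 h (a higher number here means a weaker inhibitor of growth, a lower number a stronger inhibitor of growth), and lie close together. Compound 1 holds no separate place among them, as both of its measured steps (a 1.2-fold higher number from compound 1 to compound 2 (0.09 log units; within the scatter) and a 1.3-fold lower number from compound 1 to compound 3 (0.11 log units; within the scatter)) stay within the scatter.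

Compound 4 `CN1CCN(CCCOc2cccc3nc(Nc4cc(Cl)cc(Cl)c4)ccc23)CC1` keeps the shared core and has 3,5-dichlorophenyl in place of 4-chloro-3-(trifluoromethyl)phenyl on a nitrogen on an aromatic ring. The closest parallel is compound 3, changed on the same nitrogen (a 1.3-fold lower number from compound 1 to compound 3 (0.11 log units; within the scatter)), and the remaining step (a 1.6-fold lower number from compound 2 to compound 3 (0.20 log units; within the scatter)) also stays within the scatter. Going by the values given here, no measured compound carries 3,5-dichlorophenyl, so the range is kept wide. On these steps, no change beyond the scatter is expected in this assay for compound 4. The estimate means a 1.1-fold lower number from compound 1 to compound 4 (0.03 log units; within the scatter) as the expected step. Compound 4 is estimated at 1300 nM (expected range 650 nM to 2700 nM).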

Compound 4, concentration for 50% growth inhibition: 1670 nM
Compound 4: the middle estimate sits 1.3-fold (0.11 log units) below what was measured, within the range that was stated.
By their numbers in this assay, from the lowest: compounds 3, 1, 4 and 2 (each within the scatter of the next).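

In this assay, 3,5-dichlorophenyl on the nitrogen stays within the scatter of all three earlier groups: (a 1.2-fold higher number from compound 1 to compound 4 (0.08 log units; within the scatter)), (a 1.5-fold higher number from compound 3 to compound 4 (0.19 log units; within the scatter)) and (a 1.0-fold lower number from compound 2 to compound 4 (0.01 log units; within the scatter)). Going by these compounds alone, compound 4 carries no fluorine on this phenyl, so the earlier compounds, which all carried it, did not show that this group can lose all its fluorine with no step beyond the scatter. No measurement at hand accounts for this flat result.

The compounds shown leave open whether a phenyl with an amine or a carboxylic acid in place of the halogens would give a step beyond the scatter in this assay. They also leave open whether a longer chain between the oxygen and the basic end of the molecule would change the number.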